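Methoxy for fluoro on the ring-nitrogen aryl group

The source may hold more compounds than are shown below. What is called first, only, known or untested is meant among the compounds shown, and "the series" means these compounds.

Compound 1 `S=c1oc(-c2ccc3c(c2)OCCO3)nn1CN1CCN(c2ccc(Cl)cc2)CC1` gives in a functional assay on BGC-823 cells (Homo sapiens) for antiproliferative activity, read by MTT assay, with a stated time of 48 h (on this read-out lower numbers stand for stronger inhibition and higher numbers for weaker inhibition), only the limit > 50000 nM.
Compound 2 `COc1ccc(N2CCN(Cn3nc(-c4ccc5c(c4)OCCO5)oc3=S)CC2)cc1` gives 18900 nM in this assay.
Compound 3 `Fc1ccc(N2CCN(Cn3nc(-c4ccc5c(c4)OCCO5)oc3=S)CC2)cc1` gives only the limit > 50000 nM in this assay.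

Compound 3 therefore stands at the limit of > 50000 nM in this assay, at which 2 of the 3 values shown sit, a limit and not a number, so the step that the two limits leave unreadable from compound 1 to compound 3 cannot be read. The next compound, compound 4 `COc1cccc(N2CCN(Cn3nc(-c4ccc5c(c4)OCCO5)oc3=S)CC2)c1`, differs from compound 3 in one place: 3-methoxyphenyl in place of 4-fluorophenyl on an amine nitrogen in a ring. Among the compounds with values here, two measured steps bear on this. The step of an at least 2.6-fold higher number from compound 2 to compound 3 (0.42 log units; beyond the scatter) shows that fluoro in place of methoxy raised the number, and the step of an at least 2.6-fold lower number from compound 1 to compound 2 (0.42 log units; beyond the scatter) shows methoxy in place of chloro lowering it. Both point the same way: the methoxy compound is the only one of the three with a number rather than a limit. Compound 4 carries 3-methoxyphenyl, which is not the arrangement found in compound 2, so the size of the step is uncertain. A step of an at least 1.7-fold lower number from compound 3 to compound 4 (0.25 log units; that floor lies within the scatter) toward a lower number is expected, and the value of compound 4 in this assay is estimated at 28000 nM, within 10000 nM to 60000 nM.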

Compound 4, half-maximal inhibitory concentration: > 50000 nM
Compound 4: a limit, no number; the forecaster's own chance of this, stated with the estimate: 45%; middle value at least 1.7-fold (0.25 log units) from the limit.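

3-Methoxyphenyl in place of 4-methoxyphenyl on the amine nitrogen in the ring gives an at least 2.6-fold higher number from compound 2 to compound 4 (0.42 log units; beyond the scatter), so a methoxy group on this phenyl ring does not by itself give a measurable value in this assay. Among the four compounds, only the 4-methoxyphenyl group gives a number, and the 4-chlorophenyl, 4-fluorophenyl and 3-methoxyphenyl groups all leave the value at one limit: the limit of > 50000 nM in this assay, at which 3 of the 4 values shown sit. The steps to compound 4 from compound 1 and from compound 3 cannot be read, as each joins two limits.

As far as these compounds go, how far compound 1, compound 3 and compound 4 lie past that limit stays open, so no order among them can be given. Also open, from the compounds shown here alone, is how a 4-ethoxyphenyl or 4-dimethylaminophenyl group on the same nitrogen would compare with compound 2 at 18900 nM.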